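The compounds below may be only part of what the source reports. "The series", "measured", "known", "first", "only" and "open" are said of these compounds alone.

Measured in an ADME assay on microsomes from liver (Rattus norvegicus) for metabolic stability, using NADPH, with a stated time of 10 min; on this read-out lower numbers stand for a less stable compound and higher numbers for a more stable compound:
- compound 1 `CN(C)[C@H]1CCN(c2cccc3c2C[C@H](CN(C)[C@H]2CCCc4cccnc42)NC3)C1`: 4.55%
- compound 2 `CN1CCN(Nc2cccc3c2C[C@@H](CN(C)[C@H]2CCCc4cccnc42)NC3)CC1`: 21%

Of these two compounds, compound 1 has the lower number, and the gap up to compound 2 lies beyond the usual scatter of repeated measurements. Compound 3 `CN1CC[C@H]2CN(c3cccc4c3C[C@H](CN(C)[C@H]3CCCc5cccnc53)NC4)C[C@H]21` has not yet been measured. It keeps the core of compound 1 and differs in one group, which sits on an aromatic carbon of a six-membered aromatic ring of carbon only, ortho to a fused ring and meta to a fused ring: a group of 9 heavy atoms (7 carbon, 2 nitrogen; 2 five-membered non-aromatic rings with 1 hetero atom each) in place of a group of 8 heavy atoms (6 carbon, 2 nitrogen; one five-membered non-aromatic ring with 1 hetero atom), on an aromatic carbon. The 3-(dimethylamino)pyrrolidin-1-yl group leaves, and a group with 2 five-membered non-aromatic rings takes its place.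

Going by the values given here, no measured pair shows what a change of this kind does in this assay, so any forecast is loose. Compound 1 gives 4.55%, which leaves little room downward on a scale that stops at zero. A small upward step is therefore expected, probably not beyond the scatter. The expected change is a number 5.5 percentage points higher from compound 1 to compound 3 (within the scatter). For compound 3 the estimated value is 10%, with an expected range from 3% to 24%.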

Compound 3, percent of the compound remaining: 1.78%
The estimate for compound 3 lay 8.2 percentage points above the measured number; the whole stated range lies above it.
By their numbers in this assay, from the lowest: compounds 3 and 1 (each within the scatter of the next); then compound 2.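

Going by these compounds alone, this is the first pair that differs in one place, and it gives a direct reading of the aromatic carbon ortho to a fused ring and meta to a fused ring. In this assay, replacing the 3-(dimethylamino)pyrrolidin-1-yl group with the group carrying 2 five-membered non-aromatic rings gives a number 2.8 percentage points lower from compound 1 to compound 3 (within the scatter), so compound 1 and compound 3 cannot be told apart on this read-out, even though the entering group adds a second ring and a second defined stereocentre. Nothing at hand identifies what happens to either compound in the microsomes, or accounts for this outcome.

Within the data shown here, the pair covers only two ring-bearing amine groups at this place, so it remains open whether a morpholine ring, a simple dimethylamino group, a carboxylic acid or a hydroxyl group on the same aromatic carbon would give a clearly different number in this assay. It also leaves open whether the same exchange would behave alike with a different group elsewhere on the shared core, since one pair speaks for one setting only.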